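Swapping benzyl for isopropyl on the sulfonyl group

The compounds below may be only part of what the source reports. "The series", "measured", "known", "first", "only" and "open" are said of these compounds alone.

Measured compounds:
- compound 1, `O=C(CCCC1CCN(C(=O)CCC2CCCCC2)CC1)c1ncco1`: 3 nM
- compound 2, `O=C(CCCC1CCN(S(=O)(=O)Cc2ccccc2)CC1)c1ncco1`: 600 nM

In an assay on isolated protein for inhibition of Fatty-acid amide hydrolase 1 (Homo sapiens) (on this read-out lower numbers stand for stronger inhibition and higher numbers for weaker inhibition), compound 1 gives 3 nM. Compound 2 stands at the higher of the two numbers, with 600 nM. Compound 3, `CC(C)S(=O)(=O)N1CCC(CCCC(=O)c2ncco2)CC1`, has not yet been measured; it differs from compound 2 by isopropyl in place of benzyl on a sulfonyl sulfur. Among the measured compounds shown here, no comparable step between measured compounds exists here, so the size of this change cannot be read from the data. Compound 3 is expected to give a number near that of compound 2, with a step of a 1.7-fold higher number from compound 2 to compound 3 (0.22 log units; within the scatter) expected, perhaps slightly toward weaker inhibition. The estimate for compound 3 is 1000 nM, within 200 nM to 5000 nM.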

Compound 3, half-maximal inhibitory concentration: 140 nM
Compound 3: the middle estimate sits 7.1-fold (0.85 log units) above what was measured; measured number outside the range, below it.
By their numbers in this assay, from the lowest: compound 1; then compound 3; then compound 2.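

In this assay, the group on the sulfonyl sulfur matters: isopropyl in place of benzyl gives a 4.3-fold lower number from compound 2 to compound 3 (0.63 log units; beyond the scatter), a step beyond the usual scatter. This position therefore does not depend on the six-membered aromatic ring of benzyl, and among these two sulfonyl compounds the open-chain isopropyl gives the stronger inhibition. No measurement at hand accounts for the size of this step. On these data alone, whether methyl or tert-butyl on the sulfonyl sulfur would give a lower or higher number remains open, as does the effect of a phenyl group attached directly there.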